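Cytotoxicity notes: benzyl replaced by benzoyl in compound 3

The source may report more compounds than this note shows. Statements on the series, on what has been measured and on what is new or still open speak of the compounds shown alone.

Measured so far:
compound 1 `O=C(OC[C@H]1O[C@@H](OC[C@H](O)[C@@H](O)c2ccc(O)cc2)[C@H](O)[C@@H](O)[C@@H]1O)c1ccccc1` — > 10000 nM
compound 2 `O=C(OC[C@H]1O[C@@H](OC[C@H]2O[C@@H](OCc3ccccc3)[C@H](O)[C@@H](O)[C@@H]2O)[C@H](O)[C@@H](O)[C@@H]1O)c1ccccc1` — > 10000 nM

In an ADME assay on A2780 cells (Homo sapiens) for cytotoxicity (a lower number here means a stronger inhibitor, a higher number a weaker inhibitor), compound 1 gives > 10000 nM, which is a limit of the assay rather than a number. In this assay compound 2 gives > 10000 nM, again a limit and not a number. Among the measured compounds shown here, compound 2 thus stands at the limit of this assay, as does the one other value shown: the limit of > 10000 nM in this assay, at which 2 of the 2 values shown sit.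

Compound 3 `O=C(OC[C@H]1O[C@@H](OC[C@H]2O[C@@H](OC(=O)c3ccccc3)[C@H](O)[C@@H](O)[C@@H]2O)[C@H](O)[C@@H](O)[C@@H]1O)c1ccccc1` has not been measured. It differs from compound 2 in one place: benzoyl in place of benzyl on an oxygen on a saturated carbon.

For the measured compounds named here, no step between measured compounds is available, so the size of this change cannot be read from the series. The expectation for this assay is no step beyond the usual scatter, in either direction. Compound 3 is expected at 15000 nM, within 6000 nM to 40000 nM, most likely reported again as a limit. The expected step is a step that the limit leaves unreadable from compound 2 to compound 3.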

Compound 3, half-maximal inhibitory concentration: > 10000 nM
Compound 3 ended at the assay's limit; the forecaster's own chance of this, stated with the estimate: 85%; the middle value is on the limit's open side.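

Compound 2 and compound 3 both sit at a limit of this assay, so no step can be read between them: the limit of > 10000 nM in this assay, at which 3 of the 3 values shown sit.

The compounds shown leave open whether benzoyl in place of benzyl changes the read-out at all, and which change would bring a value inside the measurable range of this assay.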